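The source may report more compounds than this note shows. Statements on the series, on what has been measured and on what is new or still open speak of the compounds shown alone.

Measured compounds in a functional assay on MCF7 cells (Homo sapiens) for cytotoxicity, read by sulforhodamine B assay, with a stated time of 72 h; on this read-out lower numbers stand for stronger inhibition and higher numbers for weaker inhibition:

- compound 1, `Cc1cc(C)nc(NS(=O)(=O)c2ccc(NCc3coc4ccccc4c3=O)cc2)n1`, gives 93600 nM
- compound 2, `O=c1c(CNc2ccc(S(=O)(=O)Nc3ncccn3)cc2)coc2ccccc12`, reaches only the assay limit, > 100000 nM
- compound 3, `Cc1cc(C)nc(NS(=O)(=O)c2ccc(N3C(=O)/C(=C/c4coc5ccccc5c4=O)N=C3c3ccccc3)cc2)n1`, gives 99700 nM

Compound 1 and compound 2 share the same core and differ in one place: pyrimidin-2-yl in place of 4,6-dimethylpyrimidin-2-yl on a sulfonamide nitrogen. This change gave an at least 1.0-fold higher number from compound 1 to compound 2 (0.02 log units; that floor lies within the scatter), and compound 2 sits at the limit of > 100000 nM in this assay, at which 1 of the 3 values shown sits. Compound 3 carries a different core from compound 1; that difference between the two cores is not broken down here. Its value and that of compound 1 lie within the usual scatter of each other.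

Compound 4, `O=C1/C(=C/c2coc3ccccc3c2=O)N=C(c2ccccc2)N1c1ccc(S(=O)(=O)Nc2ncccn2)cc1`, is not yet measured. It stands to compound 3 as compound 2 stands to compound 1, with the same change at the same place: pyrimidin-2-yl in place of 4,6-dimethylpyrimidin-2-yl on a sulfonamide nitrogen. Since the earlier example of this change left the number essentially where it was, the expected step in this assay is a 1.3-fold higher number from compound 3 to compound 4 (0.12 log units; within the scatter), resting on the step from compound 1 to compound 2. Compound 4 is therefore estimated at 130000 nM, with a fair chance that only a limit is reported.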

Compound 4, half-maximal inhibitory concentration: > 100000 nM
Compound 4: a limit, no number; the forecaster's own chance of this, stated with the estimate: 60%; the middle value does not contradict the limit.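

Carried to a second core in this assay, putting pyrimidin-2-yl in place of 4,6-dimethylpyrimidin-2-yl on the sulfonamide nitrogen gave a number no lower from compound 3 to compound 4 (the limit leaves the size open). Compound 4 reaches only a limit of the assay, > 100000 nM, and not a number. On neither core did the change bring a lower number, so nothing shown suggests that it improves this read-out, but the size of the new step cannot be read and the two steps cannot be shown to match: the same change on two cores in this assay, an at least 1.0-fold higher number (0.02 log units; that floor lies within the scatter) from compound 1 to compound 2 and a number no lower (the limit leaves the size open) from compound 3 to compound 4; the limit leaves it open whether they differ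

Going by these compounds, with so many compounds at one end of the measurable range, the series offers little room for telling small differences apart: the limit of > 100000 nM in this assay, at which 2 of the 4 values shown sit. It remains open whether a different group on the sulfonamide nitrogen, such as a longer chain ending in an amine or a carboxylic acid, would give a number clearly away from that limit on either core.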